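The compounds below may be only part of what the source reports. "The series", "measured", "known", "first", "only" and "open" are said of these compounds alone.

Measured so far:
compound 1 `CSc1cc(C)c(C(=O)N=C(N)N)cc1S(C)(=O)=O`: 6 nM
compound 2 `Cc1cc(OC(C)C)c(S(C)(=O)=O)cc1C(=O)N=C(N)N`: 19 nM

Within the data shown here, in a functional assay for inhibition of sodium/hydrogen exchanger (Oryctolagus cuniculus) (a lower number here means a stronger inhibitor, a higher number a weaker inhibitor), compound 2 gives the higher of the two numbers; compound 1 gives 6 nM, and the only step measured, a 3.2-fold higher number from compound 1 to compound 2 (0.50 log units; beyond the scatter), is modest. Compound 3 `Cc1cc(Nc2ncccn2)c(S(C)(=O)=O)cc1C(=O)N=C(N)N` differs from compound 2 by (pyrimidin-2-yl)amino in place of isopropoxy on an aromatic carbon. Among the measured compounds shown here, no measured step exchanges isopropoxy for (pyrimidin-2-yl)amino, so the single known step bears on this change only loosely. The step is therefore expected to stay within the scatter, with wide uncertainty: a 1.3-fold lower number from compound 2 to compound 3 (0.10 log units; within the scatter). Compound 3 is estimated at 15 nM, in the range 4 nM to 60 nM.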

Compound 3, half-maximal inhibitory concentration: 8.3 nM
The estimate for compound 3 lay 1.8-fold (0.26 log units) above the measured number; low and high end bracket the measured number.
By their numbers in this assay, from the lowest: compounds 1 and 3 (each within the scatter of the next); then compound 2.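

At the aromatic carbon ortho to the methylsulfonyl group, this assay tolerates a group carrying its own ring: there is a 2.3-fold lower number from compound 2 to compound 3 (0.36 log units; beyond the scatter), while a 1.4-fold higher number from compound 1 to compound 3 (0.14 log units; within the scatter). So (pyrimidin-2-yl)amino, with more heavy atoms than isopropoxy, gives the lower number of that pair and cannot be told apart from methylsulfanyl. Nothing measured here accounts for the difference from isopropoxy. The compounds shown leave open whether the ring nitrogens matter, which a phenylamino group would address. They also leave open whether the ring is needed at all, which a simple methylamino group would address.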